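The compounds below may be only part of what the source reports. "The series", "measured", "known", "first", "only" and "open" are said of these compounds alone.

Compound 1 `COc1ccc(C[C@H]2COC(=O)[C@@H]2Cc2ccc(OCC(=O)N3CCCCC3)c(OC)c2)cc1OC` was tested in an ADME assay on HeLa cells (Homo sapiens) for cytotoxicity, read by MTT assay (on this read-out higher numbers stand for weaker inhibition and lower numbers for stronger inhibition), where compound 1 gives 293000 nM. Two relatives sharing its core were measured alongside it. In this assay compound 2 `CCN(CC)C(=O)COc1ccc(C[C@H]2C(=O)OC[C@@H]2Cc2ccc(OC)c(OC)c2)cc1OC` gives 188000 nM, and compound 3 `COc1ccc(C[C@H]2COC(=O)[C@@H]2Cc2ccc(OCc3cn(Cc4ccccc4)nn3)c(OC)c2)cc1OC` gives 346000 nM. Compound 1 stands second highest of these three numbers, yet every gap falls within the usual scatter: the nearest is a 1.2-fold higher number from compound 1 to compound 3 (0.07 log units; within the scatter), the furthest is a 1.6-fold lower number from compound 1 to compound 2 (0.19 log units; within the scatter).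

Compound 4 `COc1ccc(C[C@H]2COC(=O)[C@@H]2Cc2ccc(OCc3cn(-c4ccccc4)nn3)c(OC)c2)cc1OC` has not yet been measured in this assay. It differs from compound 1 in one place: 1-phenyl-1H-1,2,3-triazol-4-yl in place of (piperidin-1-yl)carbonyl on a saturated chain carbon bound to an oxygen on an aromatic ring. The closest guide is the step in which a 1-benzyl-1H-1,2,3-triazol-4-yl replaced the same (piperidin-1-yl)carbonyl, namely a 1.2-fold higher number from compound 1 to compound 3 (0.07 log units; within the scatter), which stayed within the scatter; the related 1.8-fold higher number from compound 2 to compound 3 (0.26 log units; within the scatter) also stayed within the scatter. Going by the values given here, compound 4 carries a 1-phenyl-1H-1,2,3-triazol-4-yl where compound 3 carries a 1-benzyl-1H-1,2,3-triazol-4-yl, and no measured pair isolates that particular swap.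

Given those within-scatter steps, no change beyond the scatter is expected, so the estimated step is a 1.1-fold higher number from compound 1 to compound 4 (0.04 log units; within the scatter). Compound 4 is therefore estimated at 320000 nM, with a likely range from 150000 nM to 650000 nM.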

Compound 4, half-maximal inhibitory concentration: 124000 nM
Beside the measured number, compound 4's estimate is 2.6-fold (0.41 log units) above it, outside the stated range (below it).
By their numbers in this assay, from the lowest: compounds 4, 2, 1 and 3 (each within the scatter of the next, the first and the last beyond it).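

Phenyl in place of benzyl on an aromatic nitrogen gives the first clear movement among these close relatives in this assay: there is a 2.8-fold lower number from compound 3 to compound 4 (0.45 log units; beyond the scatter), so the group attached to the triazole matters here, even though the earlier swaps at this position showed nothing beyond the scatter. Set against the amide of compound 1, the phenyl triazole also stands apart, with a 2.4-fold lower number from compound 1 to compound 4 (0.37 log units; beyond the scatter), whereas a 1.5-fold lower number from compound 2 to compound 4 (0.18 log units; within the scatter) does not separate compound 4 from the diethylamide. So a triazole at this position is not enough in itself to shift the number, since the benzyl and phenyl versions part ways, and nothing available explains that difference.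

As far as these compounds go, with only phenyl and benzyl on that aromatic nitrogen, it remains open how the number responds to a longer chain such as 2-phenylethyl, or to a small group with no ring, such as methyl. From the compounds shown here alone, it is also open whether an amine or a carboxylic acid on the phenyl ring of compound 4 would move the number further or bring it back.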